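Methoxy Additions on a Styryl Lactam Series

A few compounds are considered here, and "the series" means these few. Any claim that something is new, unique, unknown or untested is made for them only; others in the source may bear on it.

The measured compounds:
compound 1, `COc1ccc(/C=C/C2CC=CC(=O)N2)cc1`, gives 787 uM in a functional assay on OVCAR-3 cells (Homo sapiens) for inhibition, read by sulforhodamine B assay, with a stated time of 48 h; on this read-out higher numbers stand for weaker inhibition of growth and lower numbers for stronger inhibition of growth.
compound 2, `COc1ccc(/C=C/C2CC=CC(=O)N2)c(OC)c1`, gives only a limit of the assay in this assay, > 964 uM.
compound 3, `COc1cc(/C=C/C2CC=CC(=O)N2)cc(OC)c1`, gives 232 uM in this assay.

The change from compound 1 to compound 2 is methoxy in place of hydrogen on an aromatic carbon. It gave an at least 1.2-fold higher number from compound 1 to compound 2 (0.08 log units; that floor lies within the scatter), and the size of that step is bounded only by the limit of > 964 uM in this assay, at which 1 of the 3 values shown sits. Compound 3 has the lowest number among the two measured values; the difference between its core and that of compound 1 is not broken down here.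

Compound 4, `COc1cc(/C=C/C2CC=CC(=O)N2)cc(OC)c1OC`, has not yet been measured. It differs from compound 3 by methoxy in place of hydrogen on an aromatic carbon. This is the same kind of change as that from compound 1 to compound 2, but the place differs: there the entering methoxy sat ortho to a group of 9 heavy atoms and meta to a methoxy group, whereas here it sits ortho to two methoxy groups and para to a group of 9 heavy atoms. Compound 4 is expected to show a 1.3-fold higher number from compound 3 to compound 4 (0.11 log units; within the scatter) in this assay, resting on the step from compound 1 to compound 2, an at least 1.2-fold higher number from compound 1 to compound 2 (0.08 log units; that floor lies within the scatter), which gives a weak direction only. Compound 4 is estimated at 300 uM, between 100 uM and 900 uM.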

Compound 4, concentration for growth inhibition (reported as GI): > 864 uM
Compound 4 was reported as a limit (the forecaster's own chance of this, stated with the estimate: 20%); at least 2.8-fold (0.45 log units) between middle value and limit.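

In this assay, methoxy in place of hydrogen on an aromatic carbon gave an at least 3.7-fold higher number from compound 3 to compound 4 (0.57 log units; beyond the scatter), and this step is a floor rather than a measured size. Set beside the earlier step, the change points the same way on both cores, though only this newer floor clears the usual scatter: the same change on two cores in this assay, an at least 1.2-fold higher number (0.08 log units; that floor lies within the scatter) from compound 1 to compound 2 and an at least 3.7-fold higher number (0.57 log units; beyond the scatter) from compound 3 to compound 4; the limit leaves it open whether they differ. Among the compounds shown here, this does not show that a particular size of step carries from one core to the other: both steps rest on limits of the assay, and only two pairs of compounds bear on the question.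

The compounds shown leave open whether other groups on the aromatic ring, such as an amine, a carboxylic acid or a longer chain, would move the number in the same direction as methoxy. They also leave open what replacing the amide hydrogen of the shared core would do in this assay, whether on the core of compound 1 or that of compound 3.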